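Replacing the Dimethylbenzyl Amide Cap with Cyclohexyl

The source may report more compounds than this note shows. Statements on the series, on what has been measured and on what is new or still open speak of the compounds shown alone.

Compound 1 `Cc1cc(C)cc(CNC(=O)CN(CCCCCC(=O)Nc2ccccc2N)C(=O)c2cc(C)cc(C)c2)c1` gives 5100 nM in a functional assay on A2780 cells (Homo sapiens) for cytotoxicity, read by MTT assay, with a stated time of 72 h; on this read-out higher numbers stand for weaker inhibition and lower numbers for stronger inhibition. Among the compounds with values here, compound 2 `Cc1cc(C)cc(C(=O)N(CC(=O)NCc2ccccc2)Cc2ccc(C(=O)Nc3cc(F)ccc3N)cc2)c1` gives 5400 nM in this assay, and the two numbers lie within the scatter of each other, so compound 1 stands level with the only other measured compound. Compound 3 `Cc1cc(C)cc(C(=O)N(CCCCCC(=O)Nc2ccccc2N)CC(=O)NC2CCCCC2)c1` differs from compound 1 in one place: cyclohexyl in place of 3,5-dimethylbenzyl on an amide-type nitrogen. Within the data shown here, no measured pair carries this change. The step is expected to be small, at most a slight weakening, estimated as a 1.4-fold higher number from compound 1 to compound 3 (0.14 log units; within the scatter). Compound 3 is therefore expected to give about 7000 nM, within a range from 2500 nM to 20000 nM.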

Compound 3, half-maximal inhibitory concentration: 42000 nM
Beside the measured number, compound 3's estimate is 6.0-fold (0.78 log units) below it, and the stated range ends below it.
By their numbers in this assay, from the lowest: compounds 1 and 2 (each within the scatter of the next); then compound 3.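

In this assay, this amide-type nitrogen proves sensitive to the group it carries: cyclohexyl in place of 3,5-dimethylbenzyl gives an 8.2-fold higher number from compound 1 to compound 3 (0.92 log units; beyond the scatter) and the step lies beyond the scatter. Neither group has hydrogen-bond donors or acceptors, so the two differ in ring type and heavy-atom count. Nothing measured here accounts for the step. Going by these compounds, it remains open whether the aromatic ring itself matters or the link to the ring: a cyclohexylmethyl or a pyridylmethyl group on this nitrogen would help separate these.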